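Dialkyl Sulfamide Substitution on an Aryl Urea Scaffold

The source may report more compounds than this note shows. Statements on the series, on what has been measured and on what is new or still open speak of the compounds shown alone.

Compound 3 `CCCCCCNS(=O)(=O)NC(=O)Nc1c(C(C)C)cccc1C(C)C` gives 8100 nM in an assay on liver for inhibition of sterol O-acyltransferase 1 (Rattus norvegicus), using microsomes (on this read-out lower numbers stand for stronger inhibition and higher numbers for weaker inhibition), the second highest of the three numbers recorded. Compound 1 `CC(C)NS(=O)(=O)NC(=O)Nc1c(C(C)C)cccc1C(C)C` gives 18000 nM, while compound 2 `C=CCN(CC)S(=O)(=O)NC(=O)Nc1c(C(C)C)cccc1C(C)C` gives 2100 nM. Compound 4 `CC(C)CN(CC(C)C)S(=O)(=O)NC(=O)Nc1c(C(C)C)cccc1C(C)C` has not yet been measured; it carries diisobutylamino in place of hexylamino on a sulfonyl sulfur. Going by the values given here, two measured steps bear on this change. In the step of an 8.6-fold lower number from compound 1 to compound 2 (0.93 log units; beyond the scatter), an isopropylamino group gave way to an allyl(ethyl)amino group, and in the step of a 3.9-fold higher number from compound 2 to compound 3 (0.59 log units; beyond the scatter) the allyl(ethyl)amino group was in turn exchanged for hexylamino. Both steps point the same way: the compound bearing two alkyl groups on the sulfamide nitrogen, compound 2, has the lowest number of the three. Compound 4 returns to a nitrogen bearing two alkyl groups, so a lower number than that of compound 3 is expected, of a size comparable to those earlier steps, giving an expected step of a 3.7-fold lower number from compound 3 to compound 4 (0.57 log units; beyond the scatter). Compound 4 is therefore estimated at 2200 nM, with an expected range from 700 nM to 7000 nM.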

Compound 4, half-maximal inhibitory concentration: 420 nM
The estimate for compound 4 lay 5.2-fold (0.72 log units) above the measured number; measured number below the stated range.
By their numbers in this assay, from the lowest: compound 4; then compound 2; then compound 3; then compound 1.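

In this assay, going by these compounds alone, diisobutylamino on the sulfonyl sulfur goes well past what the earlier compounds reached, with a 19-fold lower number from compound 3 to compound 4 (1.29 log units; beyond the scatter) and a 43-fold lower number from compound 1 to compound 4 (1.63 log units; beyond the scatter), so this position can carry a much lower number than the first three compounds suggested. Having two alkyl groups on the sulfamide nitrogen is not the whole story, as a 5.0-fold lower number from compound 2 to compound 4 (0.70 log units; beyond the scatter) separates two such compounds, which shows that the choice of alkyl groups also matters here. Nothing available explains why diisobutylamino gives this result.

The compounds shown leave open whether dipropylamino or a longer chain such as dihexylamino would lower the number further. They also leave open how a ring amine such as piperidine or morpholine on the sulfonyl sulfur would compare with diisobutylamino.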